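This account rests on a few compounds, and the source may have more. Where it says the series, first, only, none or still open, it means among the compounds named here.

Compound 1 `Cc1nc(S(C)(=O)=O)ccc1Oc1ncnc(OC2CCN(C(=O)O[C@@H](C)C(F)(F)F)CC2)c1F` gives 80% in a functional assay on isolated protein for inhibition of Glucose-dependent insulinotropic receptor (Rattus norvegicus), read by HTRF and cAMP accumulation; on this read-out lower numbers stand for smaller maximal responses and higher numbers for larger maximal responses.
Compound 2 `Cc1nc(S(C)(=O)=O)ccc1Oc1ncnc(OC2CCN(C(=O)c3noc(C(C)C)n3)CC2)c1F` gives 81% in this assay.

Among the measured compounds shown here, compound 2 is one of only two compounds measured so far, and in this assay its value of 81% sits within the scatter of the value of compound 1: the step was a number 1 percentage points higher from compound 1 to compound 2 (within the scatter), exchanging the group on the carbonyl carbon. Compound 3 `Cc1nc(S(C)(=O)=O)ccc1Oc1ncnc(OC2CCN(C(=O)c3noc(C(C)(C)F)n3)CC2)c1F` has not yet been measured; it differs from compound 2 by fluoro in place of hydrogen on a saturated chain carbon bound to an aromatic carbon and two saturated chain carbons. For the measured compounds named here, the only measured step does not touch this saturated chain carbon, so nothing in the data speaks directly to what a fluoro in place of hydrogen there does. Going by the values given here, the one step that exists was small, and the shared core with its carbonyl-linked ring stays the same. Compound 3 is therefore expected to give about 80%, with a range from 68% to 92%. The step from compound 2 is estimated as a number 1 percentage points lower from compound 2 to compound 3 (within the scatter), that is, no change beyond the scatter.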

Compound 3, largest response reached (reported as efficacy), in percent of the reference or control that the assay uses: 74%
Beside the measured number, compound 3's estimate is 6 percentage points above it; measured number inside the range.
By their numbers in this assay, from the lowest: compounds 3, 1 and 2 (each within the scatter of the next).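

In this assay, among the compounds shown here, the change from isopropyl to 1-fluoro-1-methylethyl gives a number 7 percentage points lower from compound 2 to compound 3 (within the scatter) and so offers the first reading at this saturated chain carbon: a fluoro in place of hydrogen there leaves the maximal response within the scatter. The wider exchange on the carbonyl carbon, read with the fluoro already in place, gives a number 6 percentage points lower from compound 1 to compound 3 (within the scatter) and likewise does not separate the two compounds. No measurement shown here bears on the reason for these results.

Going by these compounds, whether a hydroxyl or a methoxy group on this carbon, or a tert-butyl group in place of the whole 1-fluoro-1-methylethyl, would stay within the same scatter remains open. On these data alone, with all three compounds lying within the scatter of one another, it also remains open which change at this end of the molecule, if any, would move the maximal response beyond it.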